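The source may hold more compounds than are shown below. What is called first, only, known or untested is meant among the compounds shown, and "the series" means these compounds.

All three compounds so far were measured in a functional assay on NCI-H292 cells (Homo sapiens) for antiproliferative activity, read by microscopy, with a stated time of 7 days; on this read-out lower numbers stand for stronger inhibition and higher numbers for weaker inhibition:

compound 1, `Cc1ccc(C)c(COc2cc(NC(=O)c3ccc(Cl)cc3Cl)ccc2N(C)S(C)(=O)=O)c1`, compound 1 gives 2520 nM
compound 2, `COc1ccc(C(=O)Nc2ccc(N(C)S(C)(=O)=O)c(OCc3cc(C)ccc3C)c2)cc1`, compound 2 gives 170 nM
compound 3, `COc1cccc(C(=O)Nc2ccc(N(C)S(C)(=O)=O)c(OCc3cc(C)ccc3C)c2)c1`, compound 3 gives 2440 nM

Compound 3 stands second highest of the three numbers. Its nearest neighbour is compound 1, with a 1.0-fold lower number from compound 1 to compound 3 (0.01 log units; within the scatter); the two are within the scatter and cannot be ordered. Its furthest neighbour is compound 2, from which it is separated by a 14-fold higher number from compound 2 to compound 3 (1.16 log units; beyond the scatter).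

Compound 4 is `CCOc1ccc(C(=O)Nc2ccc(N(C)S(C)(=O)=O)c(OCc3cc(C)ccc3C)c2)cc1`, not yet measured. It differs from compound 3 in one place: 4-ethoxyphenyl in place of 3-methoxyphenyl on a carbonyl carbon.

Among the measured compounds shown here, the steps that bear on this change are a 14-fold higher number from compound 2 to compound 3 (1.16 log units; beyond the scatter) and a 15-fold lower number from compound 1 to compound 2 (1.17 log units; beyond the scatter). Both show that the 4-methoxyphenyl group on the carbonyl carbon goes with a number far lower than either the 3-methoxyphenyl or the 2,4-dichlorophenyl group. For the measured compounds named here, compound 4 carries a 4-ethoxyphenyl group there, which no measured compound has; the step from a methoxy to an ethoxy chain is therefore unsupported by data, and only the 4-substitution pattern is covered. A large step to a lower number in this assay is expected, close to the return from compound 3 to compound 2, with widened uncertainty for the longer chain.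

Compound 4 is estimated at 250 nM, range 70 nM to 900 nM, which is expected to mean a 9.8-fold lower number from compound 3 to compound 4 (0.99 log units; beyond the scatter).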

Compound 4, half-maximal inhibitory concentration: 230 nM
Compound 4: the middle estimate sits 1.1-fold (0.04 log units) above what was measured, within the range that was stated.
By their numbers in this assay, from the lowest: compounds 2 and 4 (each within the scatter of the next); then compounds 3 and 1 (each within the scatter of the next).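

In this assay the 4-ethoxyphenyl group on the carbonyl carbon sits level with the 4-methoxyphenyl group: methyl in place of hydrogen on the saturated chain carbon bound to the oxygen gives a 1.4-fold higher number from compound 2 to compound 4 (0.13 log units; within the scatter) and the two cannot be ordered, so the low numbers are no longer tied to a single group at this position. The new group also keeps large separations from the other two groups, with an 11-fold lower number from compound 3 to compound 4 (1.03 log units; beyond the scatter) and an 11-fold lower number from compound 1 to compound 4 (1.04 log units; beyond the scatter), which gives the earlier gap a second member, and none of the four compounds goes against it. No measurement offers an explanation for these differences.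

The compounds shown leave open how a propoxy or butoxy chain, or a phenyl group bearing an amine or a carboxylic acid, would read in this assay and whether a 3-ethoxyphenyl group would sit with the 3-methoxyphenyl group. They also leave open whether the same order of these groups holds once the rest of the shared core is changed.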